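The source may report more compounds than this note shows. Statements on the series, on what has been measured and on what is new or still open speak of the compounds shown alone.

Series on a shared core, varied on the carbon with a double bond to nitrogen. Compound 1 `Cc1c(C(=O)N/N=C\c2ccc(O)cc2)oc2cccc(O)c12` carries 4-hydroxyphenyl there; in a functional assay on PC-3 cells (Homo sapiens) for inhibition (on this read-out higher numbers stand for weaker inhibition and lower numbers for stronger inhibition), compound 1 gives 21700 nM. Compound 2 `Cc1c(C(=O)N/N=C\c2cccnc2)oc2cccc(O)c12` carries pyridin-3-yl; in this assay compound 2 reaches only the limit of >= 40000 nM. Compound 3 `Cc1c(C(=O)N/N=C\c2ccc(O)c(O)c2O)oc2cccc(O)c12` likewise reaches only the limit of >= 40000 nM. Compound 2 thus stands at the upper boundary of the numbers shown, where two of the three values sit (the limit of >= 40000 nM in this assay, at which 2 of the 3 values shown sit). Going by the values given here, the single measured step that reaches it, an at least 1.8-fold higher number from compound 1 to compound 2 (0.26 log units; that floor lies within the scatter), is itself a floor that does not separate compound 2 from compound 1 beyond the scatter.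

Compound 4 `Cc1c(C(=O)N/N=C\c2ccc(F)cc2)oc2cccc(O)c12` is the next member: 4-fluorophenyl in place of pyridin-3-yl on a carbon with a double bond to nitrogen. Among the compounds with values here, no measured step exchanges one phenyl substituent for another; the only bearing step is an at least 1.8-fold higher number from compound 1 to compound 2 (0.26 log units; that floor lies within the scatter). Returning to a six-membered ring of carbon only is therefore expected to change compound 4 little, an at least 1.4-fold lower number from compound 2 to compound 4 (0.15 log units; that floor lies within the scatter), with a fair chance that the limit is reported again. Compound 4 is estimated at 28000 nM, between 12000 nM and 60000 nM.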

Compound 4, half-maximal inhibitory concentration: >= 40000 nM
Compound 4: only a limit was reported; the forecaster's own chance of this, stated with the estimate: 40%; middle value at least 1.4-fold (0.15 log units) from the limit.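

Fluoro in place of hydroxy on an aromatic carbon gives an at least 1.8-fold higher number from compound 1 to compound 4 (0.26 log units; that floor lies within the scatter), so removing the hydroxy of 4-hydroxyphenyl is not shown to matter beyond the scatter. Both ends of the step between pyridin-3-yl and 4-fluorophenyl are limits, and that step cannot be read. In this assay, compound 1 remains the only member with a number rather than a limit, and the series gathers at the top of the range: the limit of >= 40000 nM in this assay, at which 3 of the 4 values shown sit.

As far as these compounds go, whether the groups at the limit differ from one another stays open, as does whether 4-hydroxyphenyl truly stands apart from them beyond the scatter. The compounds shown also give no reading for an amine or a carboxylic acid in place of the hydroxy on the aromatic carbon.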